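The source may report more compounds than this note shows. Statements on the series, on what has been measured and on what is new or still open speak of the compounds shown alone.

Measured so far in a physicochemical assay for pharmacokinetics; on this read-out lower numbers stand for a shorter-lived compound and higher numbers for a longer-lived compound:

compound 1, `O=C(NCc1cccs1)N1C(=O)c2ccccc2S1(=O)=O`: 0.365 h
compound 2, `O=C(NCc1ccccc1C(F)(F)F)N1C(=O)c2ccccc2S1(=O)=O`: 0.187 h
compound 3, `O=C(NCc1ccccc1)N1C(=O)c2ccccc2S1(=O)=O`: 1.02 h

Compound 1 stands second highest of the three numbers in this assay. Compound 3 lies clearly above it, a 2.8-fold higher number from compound 1 to compound 3 (0.45 log units; beyond the scatter). Compound 2 lies lower, but the gap between compound 1 and compound 2 is within the scatter, so no order between those two is claimed.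

Compound 4, `Cc1ccccc1CNC(=O)N1C(=O)c2ccccc2S1(=O)=O`, is not yet measured. Relative to compound 1 the change is 2-methylphenyl in place of thiophen-2-yl on a saturated chain carbon bound to an amide-type nitrogen.

Among the measured compounds shown here, two measured steps bear on this. The first, a 2.8-fold higher number from compound 1 to compound 3 (0.45 log units; beyond the scatter), covers the exchange of the thiophen-2-yl for a six-membered ring of carbon only. The second, a 5.5-fold higher number from compound 2 to compound 3 (0.74 log units; beyond the scatter), shows that a substituent on that ring gave a lower number than the bare phenyl. For the measured compounds named here, compound 4 carries a methyl rather than a trifluoromethyl, and no measured pair shows the methyl itself, so the second step is only a rough pointer. Taken together, a modest rise is expected, smaller than the step to compound 3.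

Compound 4 is therefore expected to give 0.6 h, within 0.25 h to 1.5 h. The expected step is a 1.6-fold higher number from compound 1 to compound 4 (0.22 log units; within the scatter).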

Compound 4, half-life: 0.792 h
The estimate for compound 4 lay 1.3-fold (0.12 log units) below the measured number, and the stated range covers the measured number.
By their numbers in this assay, from the lowest: compounds 2 and 1 (each within the scatter of the next); then compounds 4 and 3 (each within the scatter of the next).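

In this assay, the methyl group is now read directly: a 1.3-fold lower number from compound 3 to compound 4 (0.11 log units; within the scatter), so these two compounds cannot be told apart on this read-out. With methyl in place of trifluoromethyl on the same aromatic carbon, the result is a 4.2-fold higher number from compound 2 to compound 4 (0.63 log units; beyond the scatter), so a substituent on the ring does not by itself go with the low number; among these compounds, only the trifluoromethyl of compound 2 does. The change from thiophen-2-yl also gives a 2.2-fold higher number from compound 1 to compound 4 (0.34 log units; beyond the scatter), so the rise seen with phenyl in compound 3 is also seen with 2-methylphenyl.

No measurement shown gives a reason for these differences. On these data alone, it remains open whether a methoxy group or a chlorine on the aromatic carbon would read like methyl or like trifluoromethyl, and what a longer chain carrying the phenyl would give.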